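Ester Ring Size and Liver Microsome Stability

This account rests on a few compounds, and the source may have more. Where it says the series, first, only, none or still open, it means among the compounds named here.

Compound 3, `CCCCc1nc(C)c(CC(=O)OCC2CC2)c(=O)n1Cc1ccc(-c2ccccc2-c2noc(=O)[nH]2)cc1`, was measured in an ADME assay on microsomes from liver (Mus musculus) for metabolic stability, with a stated time of 30 min (on this read-out higher numbers stand for a more stable compound and lower numbers for a less stable compound), and gave 13%. Compound 2, `CCCCc1nc(C)c(CC(=O)OC2CC2)c(=O)n1Cc1ccc(-c2ccccc2-c2noc(=O)[nH]2)cc1`, gave 12.8% in this assay, and the change of cyclopropylmethyl in place of cyclopropyl on an oxygen next to a carbonyl group moved the read-out by a number 0.2 percentage points higher from compound 2 to compound 3 (within the scatter), so the two values lie within the scatter of one another. Going by the values given here, compound 1, `CCCCc1nc(C)c(CC(=O)OCC)c(=O)n1Cc1ccc(-c2ccccc2-c2noc(=O)[nH]2)cc1`, gave 12.9%; 78.4% (2 entries) in this assay; the two entries differ widely, as the several entries of compound 1 in this assay, 12.9%; 78.4% (2 entries) shows, and the pair with compound 3 has no computed step. Compound 4, `CCCCc1nc(C)c(CC(=O)OCC2CCCCC2)c(=O)n1Cc1ccc(-c2ccccc2-c2noc(=O)[nH]2)cc1`, has not been measured in this assay. It differs from compound 3 by cyclohexyl in place of cyclopropyl on a saturated chain carbon bound to an oxygen next to a carbonyl group. Among the compounds with values here, the one measured step on this oxygen, the step from compound 2 to compound 3, lay within the scatter, and no measured step covers a six-membered ring. Compound 4 is therefore expected to show a step of about a number 3 percentage points lower from compound 3 to compound 4 (within the scatter), with the estimate for compound 4 standing at 10% in a range from 3% to 25%.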

Compound 4, percent of the compound remaining: 8.9%
Estimate against measurement, compound 4: 1.1 percentage points above; low and high end bracket the measured number.
By their numbers in this assay, from the lowest: compounds 4, 2 and 3 (each within the scatter of the next).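

Going by these compounds alone, until this result, the only step on this oxygen stayed among groups carrying a three-membered ring; compound 4 extends the comparison to a six-membered ring of carbon only. Cyclohexyl in place of cyclopropyl on a saturated chain carbon bound to an oxygen next to a carbonyl group gives a number 4.1 percentage points lower from compound 3 to compound 4 (within the scatter) in this assay, and the same read-out shows a number 3.9 percentage points lower from compound 2 to compound 4 (within the scatter). Among compounds 2, 3 and 4, then, neither ring size nor the choice between cyclopropyl and cyclopropylmethyl separates the values beyond the scatter.

From the compounds shown here alone, whether an amine, a carboxylic acid or a longer open chain in this place would shift the read-out stays open. Compound 1, the ethyl ester, offers no firm reference point for these three compounds: the several entries of compound 1 in this assay, 12.9%; 78.4% (2 entries).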